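The source may report more compounds than this note shows. Statements on the series, on what has been measured and on what is new or still open speak of the compounds shown alone.

Of the compounds shown here, three of a shared core have been tested in a functional assay on Jurkat cells (Homo sapiens) for cytotoxicity, read by MTT assay, with a stated time of 72 h; a higher number here means a weaker inhibitor, a lower number a stronger inhibitor. Compound 1 `Cc1cn([C@@H]2C[C@H](c3ccccc3)N(Cc3ccccc3)O2)c(=O)[nH]c1=O` gives 19300 nM, compound 2 `Cc1cn([C@@H]2C[C@H](c3ccccc3)N(C)O2)c(=O)[nH]c1=O` gives 76600 nM, and compound 3 `CC(C)(C)N1O[C@H](n2cc(F)c(=O)[nH]c2=O)C[C@@H]1c1ccccc1` gives 60600 nM. Among these three numbers compound 3 stands second highest: its value sits within the scatter of that of compound 2, while the value of compound 1 lies beyond the scatter below it. Within the data shown here, the one step measured so far, a 4.0-fold higher number from compound 1 to compound 2 (0.60 log units; beyond the scatter), changed a group on the nitrogen of the saturated ring, not the aromatic ring.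

Compound 4 `Cc1cn([C@@H]2C[C@H](c3ccccc3)N(C(C)(C)C)O2)c(=O)[nH]c1=O` differs from compound 3 by methyl in place of fluoro on an aromatic carbon. Among the measured compounds shown here, no measured step touches this aromatic position, so the data give no direct guide, and a small group swapped for another small group at one spot is most plausibly a change within the scatter. Compound 4 is therefore estimated at 55000 nM, within a range from 20000 nM to 150000 nM. This corresponds to an expected step of a 1.1-fold lower number from compound 3 to compound 4 (0.04 log units; within the scatter).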

Compound 4, half-maximal inhibitory concentration: 72200 nM
Compound 4: middle estimate off by 1.3-fold (0.12 log units), on the low side; the measured number falls inside the stated range.
By their numbers in this assay, from the lowest: compound 1; then compounds 3, 4 and 2 (each within the scatter of the next).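

In this assay, among these compounds, this is the first measured change at this aromatic carbon, and methyl in place of fluoro (a 1.2-fold higher number from compound 3 to compound 4 (0.08 log units; within the scatter)) shows that the two groups cannot be told apart here on the shared core. Compound 4 also settles more about the amine nitrogen in the ring: tert-butyl in place of methyl (a 1.1-fold lower number from compound 2 to compound 4 (0.03 log units; within the scatter)) stays within the scatter, while tert-butyl in place of benzyl (a 3.7-fold higher number from compound 1 to compound 4 (0.57 log units; beyond the scatter)) goes beyond it, so among these three groups on that nitrogen only benzyl stands apart. No other measurement here bears on these steps.

On these data alone, whether a nitrile or an amine on the same aromatic carbon would shift the number remains open. So does whether a longer chain on the nitrogen would behave like benzyl or like tert-butyl.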